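The source may hold more compounds than are shown below. What is called first, only, known or untested is meant among the compounds shown, and "the series" means these compounds.

Measured so far in an assay on isolated protein for displacement of a labelled ligand from prostaglandin E2 receptor EP3 subtype (Homo sapiens), read by scintillation counting, with a stated time of 2 h; on this read-out lower numbers stand for stronger inhibition and higher numbers for weaker inhibition:
compound 1 `COc1ccc(Cl)cc1S(=O)(=O)NC(=O)NC/C=C1\CCCc2cnn(Cc3ccc(Cl)cc3Cl)c21`, 3 nM
compound 2 `O=C(NC/C=C1\CCCc2cnn(-c3ccc(C(F)(F)F)cc3)c21)NS(=O)(=O)c1cc(Cl)c(Cl)s1`, 0.4 nM
compound 3 `O=C(NC/C(F)=C1\CCCc2cnn(C3CCN(c4ccc(F)cc4)CC3)c21)NS(=O)(=O)c1cc(Cl)c(Cl)s1`, 13 nM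

Compound 1 holds the second highest of the three numbers in this assay: compound 3 sits above it by a gap beyond the scatter, compound 2 below it by a larger gap, also beyond the scatter.

The next compound, compound 4 `O=C(NC/C=C1\CCCc2cnn(Cc3ccc(Cl)cc3Cl)c21)NS(=O)(=O)c1cccs1`, keeps the core of compound 1 and alters only the sulfonyl end: thiophen-2-yl in place of 5-chloro-2-methoxyphenyl on a sulfonyl sulfur. Among the compounds with values here, no measured pair isolates this change. The expectation is a modest rise, a 3.3-fold higher number from compound 1 to compound 4 (0.52 log units; beyond the scatter), at the edge of the scatter. Compound 4 is estimated at 10 nM, in the range 3 nM to 30 nM.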

Compound 4, inhibition constant: 15 nM
Estimate against measurement, compound 4: 1.5-fold (0.18 log units) below; measured number inside the range.
By their numbers in this assay, from the lowest: compound 2; then compound 1; then compounds 3 and 4 (each within the scatter of the next).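

Within the data shown here, with the core of compound 1 held fixed, this is the first change isolated at the sulfonyl end: in this assay thiophen-2-yl gives a 5.0-fold higher number from compound 1 to compound 4 (0.70 log units; beyond the scatter) and so shows that the group on the sulfonyl sulfur affects the number. This single pair does not separate the change of ring from the loss of the chlorine and methoxy groups. No supporting data account for the step.

Plain phenyl on the sulfonyl sulfur would help separate these contributions. On these data alone, it remains open how 2-methoxyphenyl or 3-chlorophenyl would fare there.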